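The source may report more compounds than this note shows. Statements on the series, on what has been measured and on what is new or still open speak of the compounds shown alone.

Measured so far:
- compound 1, `CCCNC(=O)c1cc(Oc2ccc(NC(=O)c3cc4cccnc4n(-c4ccccc4)c3=O)cc2)ccn1`: 1510 nM
- compound 2, `CCCNC(=O)c1cc(Oc2ccc(NC(=O)c3cc4cccnc4n(-c4ccc(OC)cc4)c3=O)cc2)ccn1`: 8210 nM

Both compounds were tested in a functional assay on U-87MG ATCC cells for antiproliferative activity against U-87 MG (Homo sapiens), read by MTT assay, with a stated time of 72 h; a lower number here means a stronger inhibitor, a higher number a weaker inhibitor. For the measured compounds named here, compound 2 stands at the higher of the two numbers, so it is the weaker of this pair; its only neighbour, compound 1, sits at 1510 nM. Going by the values given here, the one measured step, a 5.4-fold higher number from compound 1 to compound 2 (0.74 log units; beyond the scatter), is the whole of what is known about the phenyl attached to the aromatic nitrogen of the shared core.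

Compound 3, `CCCNC(=O)c1cc(Oc2ccc(NC(=O)c3cc4cccnc4n(-c4ccc(F)c(Cl)c4)c3=O)cc2)ccn1`, has not yet been measured. It differs from compound 2 in one place: 3-chloro-4-fluorophenyl in place of 4-methoxyphenyl on an aromatic nitrogen. The step that bears on this change is a 5.4-fold higher number from compound 1 to compound 2 (0.74 log units; beyond the scatter), which shows that taking the methoxy away again should bring the number back down toward compound 1. Among the compounds with values here, what the chlorine and fluorine add on top of that has no measured counterpart in this set, so the size of their own contribution is unknown. On the strength of the methoxy step alone, a lower number is expected for compound 3 in this assay, by roughly the amount that was lost, with a wide margin for the halogens. The estimate for compound 3 is 1500 nM, expected to fall between 500 nM and 5000 nM. For compound 3 this amounts to an expected step of a 5.5-fold lower number from compound 2 to compound 3 (0.74 log units; beyond the scatter).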

Compound 3, half-maximal inhibitory concentration: 3590 nM
The estimate for compound 3 lay 2.4-fold (0.38 log units) below the measured number; measured number inside the range.
By their numbers in this assay, from the lowest: compound 1; then compound 3; then compound 2.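

In this assay the 3-chloro-4-fluorophenyl in place of 4-methoxyphenyl on the aromatic nitrogen gives a 2.3-fold lower number from compound 2 to compound 3 (0.36 log units; beyond the scatter), so the new ring recovers part of the ground lost with the methoxy, but only part. Plain phenyl stays ahead of the halogenated ring, with a 2.4-fold higher number from compound 1 to compound 3 (0.38 log units; beyond the scatter), which means that among these three compounds both substituted rings give a higher number than the unsubstituted one, and none of the three goes against this. The position therefore responds to two quite different sets of substituents in the same direction but by different amounts, and nothing measured here speaks to the reason for that.

Chlorine and fluorine enter together in compound 3, so the share of each stays unknown, and a ring carrying the fluorine alone or the chlorine alone would be needed to separate them. Also open, from the compounds shown here alone, is how this position would respond to an amine or a carboxylic acid on the ring, or to a plain alkyl chain on the nitrogen in place of the ring.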